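The source may report more compounds than this note shows. Statements on the series, on what has been measured and on what is new or still open speak of the compounds shown alone.

Of the compounds shown here, two have so far been measured in a functional assay on MKN-45 cells (Homo sapiens) for inhibition, with a stated time of 72 h; on this read-out lower numbers stand for stronger inhibition and higher numbers for weaker inhibition. Compound 1 `COc1ccc(S(=O)(=O)N2CCc3cccc(-c4ccc(N)cc4)c32)cc1` gives 162 nM in this assay, while compound 2 `COc1ccc(S(=O)(=O)N2CCc3cccc(-c4ccc([N+](=O)[O-])cc4)c32)cc1` gives 34 nM. For the measured compounds named here, compound 2 thus holds the lower of the two numbers, and the single step between them, a 4.8-fold lower number from compound 1 to compound 2 (0.68 log units; beyond the scatter), separates the pair by more than the usual scatter.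

Compound 3 `COc1ccc(S(=O)(=O)N2CCc3cccc(-c4ccc(C#N)cc4)c32)cc1` remains to be measured. It differs from compound 2 in one place: cyano in place of nitro on an aromatic carbon. Going by the values given here, only one measured step bears on this change, a 4.8-fold lower number from compound 1 to compound 2 (0.68 log units; beyond the scatter), and it concerns a different exchange at the same aromatic carbon, so it fixes no size for cyano in place of nitro. What it does show is that exchanging the group at this carbon can move the number by a modest amount in either direction. Compound 3 is therefore expected to land near compound 2, with a step of a 1.8-fold higher number from compound 2 to compound 3 (0.25 log units; within the scatter) that may well stay within the scatter. The estimate for compound 3 in this assay is 60 nM, with a range from 25 nM to 150 nM.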

Compound 3, half-maximal inhibitory concentration: 17.2 nM
Estimate against measurement, compound 3: 3.5-fold (0.54 log units) above, and the stated range ends above it.
By their numbers in this assay, from the lowest: compounds 3 and 2 (each within the scatter of the next); then compound 1.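

With cyano in place of nitro, a 2.0-fold lower number from compound 2 to compound 3 (0.30 log units; within the scatter) in this assay, so the nitro group of compound 2 and the cyano group of compound 3 cannot be told apart at this aromatic carbon, para to a large group, even though the two differ in heavy atoms and hydrogen-bond acceptors. The other new step, a 9.4-fold lower number from compound 1 to compound 3 (0.97 log units; beyond the scatter) and beyond the scatter, shows that the amino group of compound 1 now stands apart from two different groups at this carbon, not just from nitro, and nitro itself is not needed to keep the number low. No measurement shown here accounts for these differences.

Going by these compounds, whether the low numbers extend to other groups at this carbon remains open, for example a carboxylic acid, a methyl ester, a chlorine atom or an acetyl group, and the three compounds alone cannot show what sets amino apart from the other two. On these data alone, it is also open whether the same exchanges would give similar steps with the methoxy group on the sulfonyl-bearing ring replaced by a hydroxyl group or a longer ether chain.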